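Aryl semicarbazone butanoic acids in the writhing test

The source may report more compounds than this note shows. Statements on the series, on what has been measured and on what is new or still open speak of the compounds shown alone.

Three measured members share the semicarbazone-linked butanoic acid chain and differ only in the aryl part. Compound 1 `CN(C)c1ccc(/C=N/NC(=O)NCCCC(=O)O)cc1` is tested in a functional assay on the whole organism (strain Swiss Albino) for inhibition, with Mus musculus as the target, in the writhing test, at a dose of 100 mg/kg by the intraperitoneal route (on this read-out lower numbers stand for less inhibition and higher numbers for more inhibition at the one dose given (going by the name of the read-out)), and gives 93%. Compound 2 `C/C(=N\NC(=O)NCCCC(=O)O)c1cccc(N)c1` in this assay gives 89%. Compound 3 `O=C(O)CCCNC(=O)NN=C(c1ccccc1)c1ccccc1`, with two phenyl rings in its aryl part, gives in this assay 93%. Compound 3 therefore stands level with compound 1 at the digits shown, and compound 2 lies within the usual scatter of both, so the three values cannot be ordered against each other.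

The unmeasured compound 4 `O=C(O)CCCNC(=O)N/N=C(\c1ccccc1)c1ccc(Br)cc1` differs from compound 3 by bromo in place of hydrogen on an aromatic carbon. Among the measured compounds shown here, no measured pair carries this change, so its effect in this assay has no precedent here. Compound 3 already lies close to the top of the read-out, since in this assay compound 3 gives 93%, leaving little room upward. The expected step is a number 3 percentage points lower from compound 3 to compound 4 (within the scatter), that is none beyond the scatter, with at most a slight downward lean. Compound 4 is accordingly estimated at 90%, within a range from 78% to 97%.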

Compound 4, a percentage reported as inhibition, in the whole organism at one dose (the size of the read-out at that dose, not a potency): 89%
The estimate for compound 4 lay 1 percentage points above the measured number, within the range that was stated.
By their numbers in this assay, from the lowest: compounds 2, 4, 1 and 3 (each within the scatter of the next).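

In this assay, bromo in place of hydrogen on an aromatic carbon, para to a large group, gives a number 4 percentage points lower from compound 3 to compound 4 (within the scatter). Among the compounds shown here, this is the first single-place change, and it shows that one added bromine atom on a phenyl ring of compound 3 leaves compound 4 within the scatter of its parent, so the read-out at this one dose does not separate the two. Nothing available bears on the reason for this outcome.

Going by these compounds, whether an amine, a methoxy group or a chloro group on the same aromatic carbon would also stay within the scatter remains open. So does whether bromo on the second phenyl ring, or on both rings, would give a step beyond the scatter, and a single step cannot establish a trend at this position.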